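This account rests on a few compounds, and the source may have more. Where it says the series, first, only, none or still open, it means among the compounds named here.

Measured compounds in the series so far:
- Compound 1 `COc1ccccc1CN1CCN(c2ccc(C(=O)NS(=O)(=O)c3ccc(N[C@H](CCN(C)C)CSc4ccccc4)c([N+](=O)[O-])c3)cc2)CC1` gives 3.2 nM in an assay on isolated protein for displacement of a labelled ligand from Apoptosis regulator Bcl-2 (Homo sapiens), read by fluorescence polarization; a higher number here means a weaker inhibitor, a lower number a stronger inhibitor.
- Compound 2 `CN(C)CC[C@H](CSc1ccccc1)Nc1ccc(S(=O)(=O)NC(=O)c2ccc(N3CCN(Cc4ccccc4C(F)(F)F)CC3)cc2)cc1[N+](=O)[O-]` gives in this assay only a limit, < 1 nM.

Compound 2 therefore stands at the floor of the numbers shown, which is the limit of < 1 nM in this assay, at which 1 of the 2 values shown sits, and no exact number exists for it. Among the compounds with values here, the one measured step, an at least 3.2-fold lower number from compound 1 to compound 2 (0.50 log units; beyond the scatter), is the swap of methoxy for trifluoromethyl on an aromatic carbon, and it is an open-ended step because compound 2 reports only a limit.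

Compound 3 `CN(C)CC[C@H](CSc1ccccc1)Nc1ccc(S(=O)(=O)NC(=O)c2ccc(N3CCN(Cc4ccccc4-c4ccc(S(C)(=O)=O)cc4)CC3)cc2)cc1[N+](=O)[O-]` is not yet measured. It carries 4-(methylsulfonyl)phenyl in place of trifluoromethyl on an aromatic carbon. Within the data shown here, no measured step involves this entering group, so the measured step from compound 1 to compound 2 gives only the starting point, not a direction for the change at hand. The expectation is that compound 3 stays close to compound 2, with a step of an at least 1.2-fold higher number from compound 2 to compound 3 (0.07 log units; that floor lies within the scatter). Compound 3 is estimated at 1.2 nM in this assay, with a range of 0.3 nM to 5 nM.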

Compound 3, inhibition constant: < 1 nM
Compound 3: a limit, no number; the forecaster's own chance of this, stated with the estimate: 45%; middle value at least 1.2-fold (0.07 log units) from the limit.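

On an aromatic carbon ortho to a large group, compound 3 gives < 1 nM in this assay, which is a limit of the assay and not a number. This position therefore accepts 4-(methylsulfonyl)phenyl, which brings a six-membered aromatic ring and hydrogen-bond acceptors absent from trifluoromethyl, and replacing methoxy with it gives an at least 3.2-fold lower number from compound 1 to compound 3 (0.50 log units; beyond the scatter), an open-ended step. The step from the trifluoromethyl compound to the 4-(methylsulfonyl)phenyl compound cannot be read because both sit at the limit: the limit of < 1 nM in this assay, at which 2 of the 3 values shown sit.

On these data alone, how far past the limit either compound lies remains unknown, so the two groups cannot be ranked. Also open, as far as these compounds go, is whether plain phenyl, or a phenyl carrying an amine or a carboxylic acid in place of methylsulfonyl, would stay at this limit.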